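Halogen swap at the aryl ring: compound 3 to compound 4

The compounds below may be only part of what the source reports. "The series", "measured", "known", "first", "only" and "open" are said of these compounds alone.

Measured so far:
- compound 1 `COc1ccc(-c2cn3ccnc3c(-c3ccc4ncn(C5CCCCC5)c4c3)n2)cc1`: -26.3%
- compound 2 `O=Cc1ccc(-c2cn3ccnc3c(-c3ccc4ncn(C5CCCCC5)c4c3)n2)cc1`: 21.4%
- compound 3 `Fc1ccc(-c2cn3ccnc3c(-c3ccc4ncn(C5CCCCC5)c4c3)n2)cc1`: 21%

In a functional assay on SNB-75 cells (Homo sapiens) for inhibition, read by sulforhodamine B assay, with a stated time of 48 h, tested at 10 uM (a lower number here means less inhibition, a higher number more inhibition at the concentration tested (going by the name of the read-out)), compound 3 sits second highest of the three numbers. Its nearest neighbour is compound 2, and the gap a number 0.4 percentage points lower from compound 2 to compound 3 (within the scatter) lies within the scatter. Its furthest neighbour is compound 1, and the gap a number 47.3 percentage points higher from compound 1 to compound 3 (beyond the scatter) lies beyond the scatter, as does a number 47.7 percentage points higher from compound 1 to compound 2 (beyond the scatter) for the matching pair.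

The next compound, compound 4 `Clc1ccc(-c2cn3ccnc3c(-c3ccc4ncn(C5CCCCC5)c4c3)n2)cc1`, differs from compound 3 by a single substitution: chloro in place of fluoro on an aromatic carbon. Going by the values given here, no measured step exchanges one halogen for another, so the bearing is indirect. Among the compounds with values here, the one step that touches the fluoro group, a number 0.4 percentage points lower from compound 2 to compound 3 (within the scatter), was small. The two large steps, a number 47.7 percentage points higher from compound 1 to compound 2 (beyond the scatter) and a number 47.3 percentage points higher from compound 1 to compound 3 (beyond the scatter), both replace a methoxy group, and no methoxy group is involved here. Given that fluoro and formyl gave values within the scatter of each other, a second small substituent of one heavy atom is expected to leave this assay close to where compound 3 stands, with no step beyond the scatter in either direction.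

Compound 4 is therefore estimated at 24%, within the range 6% to 42%. The step this implies, a number 3 percentage points higher from compound 3 to compound 4 (within the scatter), is expected to fall within the scatter.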

Compound 4, a percentage reported as inhibition, at one concentration (the size of the read-out at that concentration, not a potency): 31.2%
The estimate for compound 4 lay 7.2 percentage points below the measured number; the measured number falls inside the stated range.
By their numbers in this assay, from the lowest: compound 1; then compounds 3, 2 and 4 (each within the scatter of the next, the first and the last beyond it).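

Going by these compounds alone, until now, the only step at this position between groups other than methoxy lay within the scatter; in this assay, the change from 4-fluorophenyl to 4-chlorophenyl, with one heavy atom leaving and one entering and no hydrogen-bond donor or acceptor on either side, gives a step beyond it: a number 10.2 percentage points higher from compound 3 to compound 4 (beyond the scatter). The separation is narrow and does not extend to formyl, as chloro in place of formyl gives a number 9.8 percentage points higher from compound 2 to compound 4 (within the scatter), so compound 2 stays within the scatter of both halogen compounds and the three cannot be put in a firm order. Chloro in place of methoxy gives the largest step seen so far, a number 57.5 percentage points higher from compound 1 to compound 4 (beyond the scatter), and compound 1 remains apart from all three other compounds, with the lowest number in the set.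

From the compounds shown here alone, whether the fluoro-to-chloro step continues with bromo or iodo at this position, and what an amine, a carboxylic acid or a longer alkyl chain would give there, remains open. Nothing available accounts for the difference between the two halogens.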